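Series notes: arylamidine naphthoquinone set, cytotoxicity

The compounds below may be only part of what the source reports. "The series", "measured", "known", "first", "only" and "open" are said of these compounds alone.

Measured so far:
compound 1 `Cc1ccc(S(=O)(=O)/N=C(/CCNC2=CC(=O)c3ccccc3C2=O)Nc2ccccc2[N+](=O)[O-])cc1` 69600 nM
compound 2 `COc1ccc(N/C(CCNC2=CC(=O)c3ccccc3C2=O)=N\S(=O)(=O)c2ccc(C)cc2)cc1OC` 60600 nM
compound 3 `COc1ccc(N/C(CCNC2=CC(=O)c3ccccc3C2=O)=N\S(=O)(=O)c2ccc(C)cc2)c(OC)c1` 83000 nM

All three values come from an ADME assay on HEK293 cells (Homo sapiens) for cytotoxicity, read by MTT assay, with a stated time of 48 h; on this read-out higher numbers stand for weaker inhibition and lower numbers for stronger inhibition. Compound 3 stands alongside compound 1 and compound 2: the steps of a 1.2-fold higher number from compound 1 to compound 3 (0.08 log units; within the scatter) and a 1.4-fold higher number from compound 2 to compound 3 (0.14 log units; within the scatter) lie within the scatter, as does a 1.1-fold lower number from compound 1 to compound 2 (0.06 log units; within the scatter). Exchanging one aryl group for another on the amine nitrogen has therefore left this assay unmoved across the set.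

Compound 4 `Cc1ccc(S(=O)(=O)/N=C(\N)CCNC2=CC(=O)c3ccccc3C2=O)cc1` differs from compound 3 by hydrogen in place of 2,4-dimethoxyphenyl on an amine nitrogen. Among the measured compounds shown here, no measured step removes the aryl group altogether, so the three aryl swaps only weakly bear on it. The three steps that are known are all within the scatter, and for compound 4 no step beyond the scatter is expected: a 1.2-fold lower number from compound 3 to compound 4 (0.06 log units; within the scatter). Compound 4 is estimated at 72000 nM, with a range from 30000 nM to 160000 nM.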

Compound 4, half-maximal inhibitory concentration: 63100 nM
For compound 4 the middle estimate is 1.1-fold (0.06 log units) above the measured one; low and high end bracket the measured number.
By their numbers in this assay, from the lowest: compounds 2, 4, 1 and 3 (each within the scatter of the next).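

In this assay the aryl group can go from the amine nitrogen altogether, not merely be exchanged for another aryl group, with every step staying within the scatter (a 1.3-fold lower number from compound 3 to compound 4 (0.12 log units; within the scatter)) (a 1.0-fold higher number from compound 2 to compound 4 (0.02 log units; within the scatter)) (a 1.1-fold lower number from compound 1 to compound 4 (0.04 log units; within the scatter)). The bare amino compound therefore sits level with 2,4-dimethoxyphenyl, 3,4-dimethoxyphenyl and 2-nitrophenyl, so an aryl group at this position is not needed to hold the number in this range. Nothing at hand explains this flat result.

Open, on these data alone, is whether a carboxylic acid or a longer alkyl chain on this nitrogen would stay equally level. Also open, as far as these compounds go, is whether any change elsewhere on the shared core would move the number beyond the scatter.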